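This account rests on a few compounds, and the source may have more. Where it says the series, first, only, none or still open, it means among the compounds named here.

Going by the values given here, in an ADME assay on the whole organism (Rattus norvegicus, strain Wistar Han) for pharmacokinetics, read by LC-MS, with a stated time of 24 h, at a dose of 3 mg/kg by the oral route (a higher number here means that a larger share of the oral dose reaches the circulation, a lower number that a smaller share of the oral dose reaches the circulation), compound 1 `CNC(=O)c1cc(C(=O)N[C@H]2[C@@H]3COC[C@@H]32)cc2c1OC[C@@]2(C)c1ccccc1` gives 54%, the higher of the two numbers available so far. Compound 2 `CNC(=O)c1cc(C(=O)N[C@H]2C[C@@H]2C)cc2c1OC[C@@]2(CO)c1ccccc1` gives 38%, and that gap lies beyond the usual scatter. However, these two compounds differ in more than one place, so the gap cannot be pinned on any single change.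

Compound 3 `CNC(=O)c1cc(C(=O)N[C@H]2[C@@H]3C[C@@H](O)C[C@@H]32)cc2c1OC[C@@]2(C)c1ccccc1` has not yet been measured. It keeps the core of compound 1 and changes only the group on the amide-type nitrogen: a group of 7 heavy atoms (6 carbon, 1 oxygen; one three-membered non-aromatic ring of carbon only, one five-membered non-aromatic ring of carbon only) in place of a group of 6 heavy atoms (5 carbon, 1 oxygen; one three-membered non-aromatic ring of carbon only, one five-membered non-aromatic ring with 1 hetero atom), on an amide-type nitrogen. Put simply, a five-membered non-aromatic ring of carbon only stands in place of a five-membered non-aromatic ring with 1 hetero atom, while the three-membered ring of carbon only remains.

Among the compounds with values here, no measured pair shows a change of this kind, so any forecast is uncertain. The only guide is compound 2 at 38%, which shows that a lower number is possible among these compounds. A small downward step is therefore expected, a number 9 percentage points lower from compound 1 to compound 3 (within the scatter), and it is not expected to lie clearly beyond the scatter. For compound 3 the estimated value in this assay is 45%, with an expected range of 25% to 62%.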

Compound 3, oral bioavailability: 32%
Compound 3: the middle estimate sits 13 percentage points above what was measured, and the stated range covers the measured number.
By their numbers in this assay, from the lowest: compounds 3 and 2 (each within the scatter of the next); then compound 1.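

This pair differs in one place only, so in this assay the change on the amide-type nitrogen can be read by itself: a number 22 percentage points lower from compound 1 to compound 3 (beyond the scatter). With the core of compound 1 held fixed, this position is clearly not indifferent to the group it carries: a five-membered non-aromatic ring of carbon only with 1 hydrogen-bond donor, in place of a five-membered non-aromatic ring with 1 hetero atom and 0 hydrogen-bond donors, goes with a smaller share of the oral dose reaching the circulation. Nothing measured here gives a reason for this fall.

The ring atoms and the donor count change together in this one step, so the compounds shown cannot say which of the two goes with the lower number; a methoxy group or an amine on the same carbon-only ring in place of the hydroxyl would help to separate them. Going by these compounds, it also remains open whether a step of this size would recur on a core carrying a different group, such as the hydroxymethyl of compound 2.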